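The compounds below may be only part of what the source reports. "The series", "measured", "known", "first", "only" and "open" are said of these compounds alone.

Values so far in a functional assay on QGY-7703 cells (Homo sapiens) for cytotoxicity, read by MTT assay, with a stated time of 24 h; on this read-out lower numbers stand for stronger inhibition and higher numbers for weaker inhibition
- compound 1 `O=C1/C(=C/c2cccnc2)CNC/C1=C\c1ccccc1F` gives 8890 nM
- compound 2 `O=C1/C(=C/c2cccnc2)CNC/C1=C\c1ccccc1C(F)(F)F` gives 3800 nM

Of these two, compound 2 has the lower number, 3800 nM, and so the stronger inhibition in this assay. Compound 3 `O=C1/C(=C/c2cccnc2)CN(S(=O)(=O)c2ccc(F)cc2)C/C1=C\c1ccccc1C(F)(F)F` keeps the core of compound 2 and changes it in one place: (4-fluorophenyl)sulfonyl in place of hydrogen on an amine nitrogen in a ring. Here (4-fluorophenyl)sulfonyl takes the place of hydrogen on an amine nitrogen in a ring.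

Within the data shown here, only one measured step is available, a 2.3-fold lower number from compound 1 to compound 2 (0.37 log units; beyond the scatter). It is modest and lies on an aromatic carbon, so it offers only a rough sense of scale for a change at this nitrogen. Among the measured compounds shown here, no measured compound carries a group there, which leaves the direction uncertain. A tentative expectation is a somewhat larger step toward a lower number, estimated as a 2.5-fold lower number from compound 2 to compound 3 (0.40 log units; beyond the scatter). For compound 3 the estimated value is 1500 nM, with an expected range of 400 nM to 6000 nM.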

Compound 3, half-maximal inhibitory concentration: 6030 nM
Beside the measured number, compound 3's estimate is 4.0-fold (0.60 log units) below it; measured number outside the range, above it.
By their numbers in this assay, from the lowest: compounds 2, 3 and 1 (each within the scatter of the next, the first and the last beyond it).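

Among these compounds, this is the first look at the amine nitrogen in the ring, and in this assay placing (4-fluorophenyl)sulfonyl there in place of hydrogen gives a 1.6-fold higher number from compound 2 to compound 3 (0.20 log units; within the scatter). So a much larger group, with its own aromatic ring, can sit on this nitrogen without moving the number beyond the usual scatter, whereas the earlier change on an aromatic carbon, a 2.3-fold lower number from compound 1 to compound 2 (0.37 log units; beyond the scatter), did go beyond it. Nothing available explains why this nitrogen accepts the group so evenly.

The compounds shown leave open whether a methyl, acetyl or benzyl group on this nitrogen would give a similar number. They also leave open whether the sulfonyl link or the fluorophenyl ring matters more, which a plain benzenesulfonyl or a 4-fluorobenzoyl group could begin to separate.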